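The compounds below may be only part of what the source reports. "The series", "measured", "known", "first", "only" and "open" are said of these compounds alone.

Compound 3 `Cc1c(C(=O)N/N=C\c2cccc(O)c2O)oc2cccc(O)c12` carries a 2,3-dihydroxyphenyl group on the carbon doubly bonded to nitrogen and gives 12200 nM in a functional assay on PC-3 cells (Homo sapiens) for inhibition; a higher number here means a weaker inhibitor, a lower number a stronger inhibitor. Among the numbers known so far it sits highest, though compound 2 `Cc1c(C(=O)N/N=C\c2c(O)cccc2F)oc2cccc(O)c12`, at 8050 nM, is separated from it only by a 1.5-fold higher number from compound 2 to compound 3 (0.18 log units; within the scatter). Compound 1 `Cc1c(C(=O)N/N=C\c2ccccc2F)oc2cccc(O)c12` reaches only the limit of >= 40000 nM, a boundary of the assay rather than a number. The steps of an at least 4.9-fold lower number from compound 1 to compound 2 (0.69 log units; beyond the scatter) and an at least 3.2-fold lower number from compound 1 to compound 3 (0.51 log units; beyond the scatter) show that adding a hydroxy group to that ring brought a clearly lower number. Compound 4 `Cc1c(C(=O)N/N=C\c2cccc(F)c2O)oc2cccc(O)c12` differs from compound 3 by fluoro in place of hydroxy on an aromatic carbon, keeping one hydroxy and one fluoro, as compound 2 does. Because compound 2 gives 8050 nM, compound 4 is expected to land near it, a step of a 1.4-fold lower number from compound 3 to compound 4 (0.13 log units; within the scatter) and an estimated 9000 nM within 3500 nM to 25000 nM.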

Compound 4, half-maximal inhibitory concentration: 12700 nM
For compound 4 the middle estimate is 1.4-fold (0.15 log units) below the measured one; low and high end bracket the measured number.
By their numbers in this assay, from the lowest: compounds 2, 3 and 4 (each within the scatter of the next). At a limit, above all of these: compound 1.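

In this assay, fluoro in place of hydroxy, ortho to a hydroxy group, makes no readable difference, the step being a 1.0-fold higher number from compound 3 to compound 4 (0.02 log units; within the scatter), so this second hydroxy is not needed to keep the number. Rearranging the ring to 3-fluoro-2-hydroxyphenyl also separates nothing, with a 1.6-fold higher number from compound 2 to compound 4 (0.20 log units; within the scatter). The gain over the ring without a hydroxy holds as well, at an at least 3.1-fold lower number from compound 1 to compound 4 (0.49 log units; beyond the scatter), though that step is only a bound, since compound 1 stands at a limit: the limit of >= 40000 nM in this assay, at which 1 of the 4 values shown sits.

From the compounds shown here alone, whether an amine or a carboxylic acid at this position would give a lower number remains open.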